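Replacing dimethylamino with trifluoromethyl on a shared core

The source may report more compounds than this note shows. Statements on the series, on what has been measured and on what is new or still open speak of the compounds shown alone.

In a functional assay on HepG2 cells (Homo sapiens) for antiproliferative activity, read by MTT assay, with a stated time of 48 h (a higher number here means a weaker inhibitor, a lower number a stronger inhibitor), compound 1 `CCOc1ccc(NC(=O)Nc2cccc(CNc3nccnc3Cl)c2)cc1` gives 7050 nM, and compound 2 `COc1ccc(NC(=O)Nc2cccc(CNc3nccnc3Cl)c2)cc1` gives 12000 nM. The gap between them is a 1.7-fold higher number from compound 1 to compound 2 (0.23 log units; within the scatter), so ethoxy and methoxy cannot be told apart here. Compound 3 `CN(C)c1ccc(NC(=O)Nc2cccc(CNc3nccnc3Cl)c2)cc1` gives > 40000 nM, which is a limit of the assay and not a number. That leaves compound 3 at the weak end of the three, at the limit of > 40000 nM in this assay, at which 1 of the 3 values shown sits.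

Compound 4 `O=C(Nc1ccc(C(F)(F)F)cc1)Nc1cccc(CNc2nccnc2Cl)c1` keeps the shared core and carries trifluoromethyl in place of dimethylamino on an aromatic carbon. For the measured compounds named here, two measured steps concern this same place: an at least 5.6-fold higher number from compound 1 to compound 3 (0.75 log units; beyond the scatter) and an at least 3.3-fold higher number from compound 2 to compound 3 (0.52 log units; beyond the scatter). In both, the arrival of dimethylamino goes with a higher number, and both sizes are only lower bounds. Going by the values given here, no measured compound carries trifluoromethyl, so the evidence is indirect. Judged by an at least 5.6-fold higher number from compound 1 to compound 3 (0.75 log units; beyond the scatter), the loss of dimethylamino is expected to bring a lower number, by a modest step of similar size. The expected step is an at least 5.0-fold lower number from compound 3 to compound 4 (0.69 log units; beyond the scatter). Compound 4 is estimated at 8000 nM, with an expected range from 2500 nM to 30000 nM.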

Compound 4, half-maximal inhibitory concentration: 5050 nM
Compound 4: middle estimate off by 1.6-fold (0.20 log units), on the high side; the measured number falls inside the stated range.
By their numbers in this assay, from the lowest: compounds 4, 1 and 2 (each within the scatter of the next, the first and the last beyond it). At a limit, above all of these: compound 3.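

Until now, this place on the aromatic ring had shown only that dimethylamino goes with a higher number than ethoxy or methoxy; trifluoromethyl adds a group with no oxygen or nitrogen, and in this assay the change gives an at least 7.9-fold lower number from compound 3 to compound 4 (0.89 log units; beyond the scatter). Set against the two ether groups, the result splits: a 2.4-fold lower number from compound 2 to compound 4 (0.38 log units; beyond the scatter), a modest gain, whereas a 1.4-fold lower number from compound 1 to compound 4 (0.14 log units; within the scatter), so trifluoromethyl and ethoxy cannot be told apart here and the two quite different groups serve about equally at this place. Among the four compounds, only compound 3 stands apart, and the first step can be read only as a lower bound, since the value of compound 3 is a limit: the limit of > 40000 nM in this assay, at which 1 of the 4 values shown sits.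

The compounds shown do not tell whether a simple amine, with its nitrogen carrying hydrogens in place of the two methyl groups, would fall as far as dimethylamino does, or whether a nitrile, a chlorine atom or a longer chain such as propoxy would give a lower number than compound 4. They also leave open whether any change to the shared core itself would matter more than these changes at this one place.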